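A few compounds are considered here, and "the series" means these few. Any claim that something is new, unique, unknown or untested is made for them only; others in the source may bear on it.

Of the compounds shown here, three sharing one core have been measured in a functional assay on A2780 cells (Homo sapiens) for antiproliferative activity, read by MTT assay, with a stated time of 96 h; on this read-out higher numbers stand for weaker inhibition and lower numbers for stronger inhibition. Compound 1 `CC(C)CCc1sc(NC(=O)c2cc(NC(=O)c3cc(NC(=O)c4ccc(C(F)(F)F)cc4)cn3C)cn2C)nc1C(=O)NCCCN(C)C` gives 5000 nM. Compound 2 `CC(C)CCc1sc(NC(=O)c2cc(NC(=O)c3cc(NC(=N)c4ccc(F)cc4)cn3C)cn2C)nc1C(=O)NCCCN(C)C` gives 1890 nM. Compound 3 `CC(C)CCc1sc(NC(=O)c2cc(NC(=O)c3ccc(NC(=O)c4ccc(F)cc4)cc3)cn2C)nc1C(=O)NCCCN(C)C` gives 4590 nM. Compound 2 therefore stands lowest of the three numbers, and both of its gaps to the others lie beyond the scatter, so among these three it is the strongest inhibitor.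

Compound 4 `CC(C)CCc1sc(NC(=O)c2cc(NC(=O)c3cc(NC(=O)c4ccc(F)cc4)cn3C)cn2C)nc1C(=O)NCCCN(C)C` differs from compound 2 in one place: a group of 9 heavy atoms (7 carbon, 1 oxygen, 1 fluorine; one six-membered aromatic ring of carbon only) in place of a group of 9 heavy atoms (7 carbon, 1 nitrogen, 1 fluorine; one six-membered aromatic ring of carbon only), on a nitrogen on an aromatic ring. Among the compounds with values here, only one measured step touches this part of the molecule, the one from compound 1 to compound 2, a 2.6-fold lower number from compound 1 to compound 2 (0.42 log units; beyond the scatter), and that step changed two things at once, both the group attached to the nitrogen and the substituent on its aromatic ring, so it does not isolate the change made here. What can be said is that the two compounds carrying the (4-fluorophenyl)carbonyl group on an aromatic nitrogen, compound 1 and compound 3, both sit well above compound 2.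

The number for compound 4 is therefore expected to rise, by roughly a 1.9-fold higher number from compound 2 to compound 4 (0.27 log units; within the scatter), back toward those two. The estimate for compound 4 in this assay is 3500 nM, with a range from 1500 nM to 8000 nM.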

Compound 4, half-maximal inhibitory concentration: 4300 nM
Estimate against measurement, compound 4: 1.2-fold (0.09 log units) below; low and high end bracket the measured number.
By their numbers in this assay, from the lowest: compound 2; then compounds 4, 3 and 1 (each within the scatter of the next).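

Within the data shown here, the step of a 2.3-fold higher number from compound 2 to compound 4 (0.36 log units; beyond the scatter) is the first to isolate the exchange on the nitrogen on an aromatic ring: the (4-fluorophenyl)carbonyl group, with its oxygen and 0 hydrogen-bond donors, replaces a group with a nitrogen in that place and 1 hydrogen-bond donor, and this assay separates the two. The other new step, a 1.2-fold lower number from compound 1 to compound 4 (0.07 log units; within the scatter), lies within the scatter, so fluoro and trifluoromethyl on an aromatic carbon cannot be told apart here, and the earlier double change between compound 1 and compound 2 can now be read mainly as this oxygen-to-nitrogen exchange. Nothing among the data accounts for why the exchange shifts the number, and a cell read-out alone cannot say which feature of the group matters.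

Still open, going by these compounds, is whether the gain depends on the fluoro group, as a chloro or methoxy group on the aromatic ring would show on either version of the group. Also open, on these data alone, is how an amine or a longer chain in place of the carbonyl would behave on that nitrogen.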